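This account rests on a few compounds, and the source may have more. Where it says the series, first, only, none or still open, it means among the compounds named here.

Compound 1, `O=C(CSc1nc(Nc2ccccc2)c2ccccc2n1)Nc1cccc(Br)c1`, is the starting point. In a functional assay on NCI-H1975 cells (Homo sapiens) for inhibition, read by MTT assay, with a stated time of 72 h (a higher number here means a weaker inhibitor, a lower number a stronger inhibitor), compound 1 gives 10100 nM. Of the three measured numbers this is the lowest, but the other two fall within the usual scatter of it, so no ranking can be read from them. Compound 2, `O=C(CSc1nc(Nc2ccccc2)c2ccccc2n1)Nc1cccc([N+](=O)[O-])c1`, gives 17900 nM in this assay, and compound 3, `O=C(CSc1nc(Nc2ccccc2)c2ccccc2n1)Nc1ccc(Br)cc1`, gives 10600 nM. The step of a 1.8-fold higher number from compound 1 to compound 2 (0.25 log units; within the scatter) puts nitro in place of bromo on the ring attached to the amide-type nitrogen; the step of a 1.0-fold higher number from compound 1 to compound 3 (0.02 log units; within the scatter) puts 4-bromophenyl in place of 3-bromophenyl on that nitrogen; and the step of a 1.7-fold lower number from compound 2 to compound 3 (0.23 log units; within the scatter) puts 4-bromophenyl in place of 3-nitrophenyl there. None of these moves leaves the range of ordinary repeat measurements.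

Compound 4, `CCc1ccc(NC(=O)CSc2nc(Nc3ccccc3)c3ccccc3n2)cc1`, has not been measured. It differs from compound 1 as follows: 4-ethylphenyl in place of 3-bromophenyl on an amide-type nitrogen. The shared core, the carbonyl and the amide-type nitrogen are untouched; only the ring on that nitrogen changes. For the measured compounds named here, the expectation rests on the steps of a 1.0-fold higher number from compound 1 to compound 3 (0.02 log units; within the scatter) and a 1.8-fold higher number from compound 1 to compound 2 (0.25 log units; within the scatter), which also changed only that ring and stayed within the scatter. A fresh group on the same ring is therefore expected to leave this assay roughly where it was, with the step of a 1.0-fold lower number from compound 1 to compound 4 (0.00 log units; within the scatter) expected to stay within the scatter. Compound 4 is estimated at 10000 nM, within 4000 nM to 25000 nM.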

Compound 4, half-maximal inhibitory concentration: 9910 nM
For compound 4 the middle estimate is 1.0-fold (0.00 log units) above the measured one; the range from low to high includes it.
By their numbers in this assay, from the lowest: compounds 4, 1, 3 and 2 (each within the scatter of the next).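

Compound 4 carries 4-ethylphenyl, a group of carbon only, on the amide-type nitrogen, and in this assay the result is a 1.0-fold lower number from compound 1 to compound 4 (0.01 log units; within the scatter). The comparisons with the other two compounds read the same way: a 1.1-fold lower number from compound 3 to compound 4 (0.03 log units; within the scatter), where bromo gives way to ethyl on the ring, and a 1.8-fold lower number from compound 2 to compound 4 (0.26 log units; within the scatter). Neither bromo nor nitro is therefore needed to keep the number in this range, and all four compounds lie within the scatter of one another, so the earlier flat picture now extends to an alkyl group, and no order can be drawn among them; nothing measured here explains why this ring accepts such different groups.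

Still open, going by these compounds, is whether a group of another kind on this ring, such as an amine, a carboxylic acid or a chain longer than ethyl, would take the number outside the scatter. Also open is what happens when the shared core itself changes, since every compound shown keeps it intact and varies only the ring on the amide-type nitrogen.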